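The source may hold more compounds than are shown below. What is called first, only, known or untested is meant among the compounds shown, and "the series" means these compounds.

Within the data shown here, in an ADME assay on BHK-21 cells (Mesocricetus auratus) for cytotoxicity, read by MTT assay, with a stated time of 72 h (on this read-out higher numbers stand for lower toxicity in this test and lower numbers for higher toxicity in this test), three compounds have numbers so far. Compound 1 `NS(=O)(=O)c1ccc(N2N=C(c3ccccc3)CC2c2ccccc2F)cc1` gives 21000 nM, compound 2 `NS(=O)(=O)c1ccc(N2N=C(c3ccccc3)CC2c2ccccc2Cl)cc1` gives 13000 nM, and compound 3 `NS(=O)(=O)c1ccc(N2N=C(c3ccc(Oc4ccccc4)cc3)CC2c2ccccc2)cc1` gives 11000 nM. All three numbers lie within the usual scatter of one another, so compound 3 stands level with the other two and cannot be set apart from them.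

Compound 4 `Cc1ccccc1C1CC(c2ccc(Oc3ccccc3)cc2)=NN1c1ccc(S(N)(=O)=O)cc1` is compound 3 with a single change, methyl in place of hydrogen on an aromatic carbon, which turns phenyl to 2-methylphenyl. Among the measured compounds shown here, no measured step shows this exact swap. For the measured compounds named here, the only measured step is a different swap on an aromatic carbon, chloro in place of fluoro, which gives a 1.6-fold lower number from compound 1 to compound 2 (0.21 log units; within the scatter). On that single step, no change beyond the scatter is expected in this assay, and no direction can be favoured. The expected step is no change at the digits printed from compound 3 to compound 4 (within the scatter). For compound 4, the estimated value is 11000 nM, with an expected range from 5500 nM to 22000 nM.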

Compound 4, half-maximal cytotoxic concentration: 7000 nM
Compound 4: the middle estimate sits 1.6-fold (0.20 log units) above what was measured, within the range that was stated.
By their numbers in this assay, from the lowest: compounds 4, 3, 2 and 1 (each within the scatter of the next, the first and the last beyond it).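

On the aromatic carbon ortho to a large group, the change from phenyl to 2-methylphenyl gives, in this assay, a 1.6-fold lower number from compound 3 to compound 4 (0.20 log units; within the scatter) as the measured step. With the rest of compound 3 held fixed, only hydrogen had been seen at this position before, and this first added carbon group leaves the number level with it, so the position tolerates methyl in this test without a readable shift. Nothing measured here explains this result or shows what methyl does to the compound.

On these data alone, whether a longer chain, an amine or a carboxylic acid at this position would move the number beyond the scatter stays open. Also open, as far as these compounds go, is whether methyl would behave the same way at this position with other groups elsewhere on the shared core.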